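Mirror-Image Methyl: From Compound 3 to Compound 4

The source may report more compounds than this note shows. Statements on the series, on what has been measured and on what is new or still open speak of the compounds shown alone.

Of the compounds shown here, three have been measured in an assay on HEK293 cells with D(4) dopamine receptor (Homo sapiens) as the target, read by FLIPR; a lower number here means a smaller maximal response, a higher number a larger maximal response. Compound 1 `O=[N+]([O-])c1ccccc1N1CCN(Cc2nc3ccccc3[nH]2)CC1` gives 40%, compound 2 `CS(=O)(=O)c1cccnc1N1CCN(Cc2nc3ccccc3[nH]2)CC1` gives 27%, and compound 3 `C[C@H]1CN(c2ccccn2)CCN1Cc1nc2ccccc2[nH]1` gives 43%. Compound 3 has the highest of the three numbers, but compound 1 lies within the scatter of it, so no order between those two can be claimed; only compound 2 sits clearly beyond the scatter, lower.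

Compound 4 `C[C@@H]1CN(c2ccccn2)CCN1Cc1nc2ccccc2[nH]1` is the next step: the two compounds have the same atoms and bonds and differ only in configuration as drawn: 1 of 1 stereo elements differ; a stereocentre at a saturated ring carbon is drawn S in compound 3 and R in compound 4. Among the compounds with values here, no measured pair shows what such a change does here, so the expected step of a number 8 percentage points lower from compound 3 to compound 4 (within the scatter) is guessed as small, somewhat downward, and possibly within the scatter. Compound 4 is expected to give about 35% in this assay, between 20% and 50%.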

Compound 4, largest response reached (reported as efficacy), in percent of the reference or control that the assay uses: 34%
The estimate for compound 4 lay 1 percentage points above the measured number, and the stated range covers the measured number.
By their numbers in this assay, from the lowest: compounds 2, 4, 1 and 3 (each within the scatter of the next, the first and the last beyond it).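

In this assay, turning the stereocentre at the saturated ring carbon from S to R gives a number 9 percentage points lower from compound 3 to compound 4 (within the scatter). Within the data shown here, this is the first measured pair to isolate that change, and at this position the mirror-image arrangement of the methyl shows no difference that can be told from scatter. The comparison is a clean one, with no other structural change to weigh: the fact that compounds 3 and 4 differ only in the configuration as drawn

On these data alone, whether configuration at this ring carbon would count for more with an ethyl or hydroxymethyl group in place of the methyl stays open. Also open, as far as these compounds go, is what the same ring would give with no methyl at all.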